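The source may hold more compounds than are shown below. What is called first, only, known or untested is meant among the compounds shown, and "the series" means these compounds.

Compound 1 `CN(C)Cc1cc(/C=C/C(=O)/C=C(O)/C=C/c2ccc(F)cc2)ccc1O`: 22300 nM
Compound 2 `Cc1ccc(/C=C/C(O)=C/C(=O)/C=C/c2ccc(O)c(CN(C)C)c2)cc1`: 22000 nM
Compound 3 `CN(C)Cc1cc(/C=C/C(=O)/C=C(O)/C=C/c2ccc(O)cc2)ccc1O`: 7600 nM

In a functional assay, with a stated time of 19 h (on this read-out lower numbers stand for stronger inhibition and higher numbers for weaker inhibition), compound 3 gives the lowest number of the three, 7600 nM. Compound 4 `CN(C)Cc1cc(/C=C/C(=O)/C=C(O)/C=C/c2cccc(O)c2)ccc1O` has the same atoms, joined differently: 3-hydroxyphenyl in place of 4-hydroxyphenyl on a double-bonded chain carbon bound to a double-bonded chain carbon.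

The closest evidence comes from changes to the substituent on that same ring. These are a 2.9-fold lower number from compound 1 to compound 3 (0.47 log units; beyond the scatter) and a 2.9-fold lower number from compound 2 to compound 3 (0.46 log units; beyond the scatter), both modest, while a 1.0-fold lower number from compound 1 to compound 2 (0.01 log units; within the scatter) stays within the scatter. Among the compounds with values here, no measured compound shows what moving the hydroxy group does, so the expectation is loose: part of that modest gain may be lost. The expected step is a 1.4-fold higher number from compound 3 to compound 4 (0.16 log units; within the scatter). Compound 4 is estimated at 11000 nM, with an expected range of 4000 nM to 27000 nM.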

Compound 4, half-maximal inhibitory concentration: 6900 nM
Compound 4: the middle estimate sits 1.6-fold (0.20 log units) above what was measured, and the stated range covers the measured number.
By their numbers in this assay, from the lowest: compounds 4 and 3 (each within the scatter of the next); then compounds 2 and 1 (each within the scatter of the next).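

In this assay, moving the hydroxy group, 3-hydroxyphenyl in place of 4-hydroxyphenyl, gives a 1.1-fold lower number from compound 3 to compound 4 (0.04 log units; within the scatter), so the ring accepts this shift with no readable change. The advantage over the non-hydroxy rings remains after the move, with a 3.2-fold lower number from compound 2 to compound 4 (0.50 log units; beyond the scatter) and a 3.2-fold lower number from compound 1 to compound 4 (0.51 log units; beyond the scatter). No measurement available here explains why the two hydroxy placements read alike. On these data alone, how a carboxylic acid or an amine in place of the hydroxy group would read remains open. So does whether plain phenyl, with no substituent, would keep the advantage.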